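The source may report more compounds than this note shows. Statements on the series, on what has been measured and on what is new or still open speak of the compounds shown alone.

Measured so far in a functional assay (aorta) with Rattus norvegicus as the target; on this read-out lower numbers stand for lower potency and higher numbers for higher potency (the scale is a negative logarithm):
Compound 1 `CC1(C)C=C(n2ccccc2=O)c2cc(C(=O)c3cccs3)ccc2O1` gives 6.4.
Compound 2 `Cc1ccccc1C(=O)c1ccc2c(c1)C(n1ccccc1=O)=CC(C)(C)O2` gives 6.83.
Compound 3 `CC1(C)C=C(n2ccccc2=O)c2cc(C(=N)NO)ccc2O1` gives 5.99.

Compound 3 therefore stands lowest of the three, separated from both others by more than the usual scatter. The step to compound 4 `CC(=O)Oc1ccc2c(c1)C(n1ccccc1=O)=CC(C)(C)O2` is a group of 4 heavy atoms (2 carbon, 2 oxygen; no ring) in place of a group of 4 heavy atoms (1 carbon, 2 nitrogen, 1 oxygen; no ring), on an aromatic carbon. Within the data shown here, no measured step introduces an acetoxy group, so the guidance is indirect. The steps of a number 0.41 log units lower from compound 1 to compound 3 (beyond the scatter) and a number 0.84 log units lower from compound 2 to compound 3 (beyond the scatter) show that compound 3, carrying the smaller group, sits below the two compounds carrying larger ring-bearing groups in this assay. The acetoxy group brings no ring and is of similar size to the group it replaces, so only a small rise, if any, is expected. Compound 4 is estimated at 6.2, plausibly between 5.5 and 6.9, an expected step of a number 0.21 log units higher from compound 3 to compound 4 (within the scatter).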

Compound 4, logarithm of the reciprocal of the active concentration, log(1/C): 5.6
Beside the measured number, compound 4's estimate is 0.60 log units above it, and the stated range covers the measured number.
By their numbers in this assay, from the lowest: compound 4; then compound 3; then compound 1; then compound 2.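

In this assay, acetoxy on this aromatic carbon gives the lowest number of the four compounds (a number 0.39 log units lower from compound 3 to compound 4 (beyond the scatter)). The two groups in that step have the same count of heavy atoms, yet only the leaving group has hydrogen-bond donors, so matching heavy-atom count does not give matching numbers here. Acetoxy also falls short of both ring-bearing carbonyl groups (a number 1.23 log units lower from compound 2 to compound 4 (beyond the scatter)) and (a number 0.80 log units lower from compound 1 to compound 4 (beyond the scatter)).

Nothing available explains these steps. From the compounds shown here alone, whether an amine or a carboxylic acid on this carbon would stay near acetoxy or approach the carbonyl groups remains open.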